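Title: A Methyl Added to a Hydroxamate with a Low Number

A few compounds are considered here, and "the series" means these few. Any claim that something is new, unique, unknown or untested is made for them only; others in the source may bear on it.

Of the compounds shown here, two have been tested in an assay on isolated protein for inhibition of protein deacetylase HDAC6 (Homo sapiens), read by fluorescence, with a stated time of 1 h, tested at 100 nM; on this read-out lower numbers stand for less inhibition and higher numbers for more inhibition at the one concentration tested (going by the name of the read-out). Compound 1 `Cc1ccc(CN2CCC(c3noc(COc4ccc(/C=C/C(=O)NO)cc4)n3)CC2)cc1` gives 76% in this assay. Compound 2 `O=C(CCc1ccc(OCc2nc(C3CCN(Cc4ccccc4)CC3)no2)cc1)NO` gives 22% in this assay, the lowest of the two numbers shown, and its nearest neighbour, compound 1, sits far above it, a gap beyond the scatter. Compound 1 and compound 2 differ in more than one place, so nothing links their gap to any single change.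

Compound 3 `Cc1ccc(CN2CCC(c3noc(COc4ccc(CCC(=O)NO)cc4)n3)CC2)cc1` has not yet been measured. It is compound 2 with one difference: methyl in place of hydrogen on an aromatic carbon. Within the data shown here, no measured pair shows the effect of that change on its own. Since compound 2 gives only 22%, the expected step is a small rise, possibly none beyond the scatter, and the estimated step is a number 10 percentage points higher from compound 2 to compound 3 (within the scatter). Compound 3 is therefore expected to give about 32% in this assay, within a range from 10% to 60%.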

Compound 3, a percentage reported as inhibition, at one concentration (the size of the read-out at that concentration, not a potency): 28%
The estimate for compound 3 lay 4 percentage points above the measured number; measured number inside the range.
By their numbers in this assay, from the lowest: compounds 2 and 3 (each within the scatter of the next); then compound 1.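

In this assay, methyl in place of hydrogen on this aromatic carbon, phenyl to 4-methylphenyl, gives a number 6 percentage points higher from compound 2 to compound 3 (within the scatter), so with the saturated chain this added carbon cannot be told apart from no change. With the methyl kept in place, 2-(hydroxycarbamoyl)ethyl in place of 2-(hydroxycarbamoyl)ethenyl gives a number 48 percentage points lower from compound 1 to compound 3 (beyond the scatter), which places a large step at that chain, in a single change, rather than at the methyl. Nothing available explains either step.

On these data alone, it remains open whether methyl counts for as little when the 2-(hydroxycarbamoyl)ethenyl chain is present. The compounds shown also leave open what a methoxy group, a chlorine atom or an amine on the same aromatic carbon would do to the number in this assay.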